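The source may report more compounds than this note shows. Statements on the series, on what has been measured and on what is new or still open speak of the compounds shown alone.

Compound 1, `CN(C[C@H]1Cc2c(cccc2N2CCN(C3COC3)CC2)CN1)[C@H]1CCCc2cccnc21`: 381 nM
Compound 2, `Cc1cnc(CN(C)C[C@H]2Cc3c(cccc3N3CCNCC3)CN2)c(C)c1`: 21.4 nM
Compound 3, `CN(C[C@@H]1Cc2c(cccc2N2CCNCC2)CN1)[C@H]1CCCc2cccnc21`: 313 nM

In a functional assay on CCRF-CEM cells for antagonist activity at C-X-C chemokine receptor type 4 (Homo sapiens), read by calcium flux, with stated times of 25 min and 90 s (on this read-out higher numbers stand for weaker inhibition and lower numbers for stronger inhibition), compound 1 has the highest of the three numbers. Compound 3 comes closest, with a gap that lies within the scatter, while compound 2 lies far beyond it. The next compound, compound 4, `CN(C[C@H]1Cc2c(cccc2N2CCNC(C)(C)C2)CN1)[C@H]1CCCc2cccnc21`, differs from compound 1 in one place: 3,3-dimethylpiperazin-1-yl in place of 4-(oxetan-3-yl)piperazin-1-yl on an aromatic carbon. The change swaps one group on the same aromatic carbon for another with one hydrogen-bond donor and two acceptors. Because compound 3, at 313 nM, sits within the scatter of compound 1, a modest step at most is expected, a 1.9-fold lower number from compound 1 to compound 4 (0.28 log units; within the scatter), leaning toward stronger inhibition. Compound 4 is estimated at 200 nM, with a likely range from 70 nM to 600 nM.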

Compound 4, half-maximal inhibitory concentration: 33.9 nM
Beside the measured number, compound 4's estimate is 5.9-fold (0.77 log units) above it; measured number outside the range, below it.
By their numbers in this assay, from the lowest: compounds 2 and 4 (each within the scatter of the next); then compounds 3 and 1 (each within the scatter of the next).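

In this assay the group on this aromatic carbon clearly matters: 3,3-dimethylpiperazin-1-yl in place of 4-(oxetan-3-yl)piperazin-1-yl brings an 11-fold lower number from compound 1 to compound 4 (1.05 log units; beyond the scatter) on a single change to the core of compound 1. That swap removes the four-membered ring and adds a hydrogen-bond donor and two methyl groups at once, so these parts cannot be told apart here. Nothing measured here explains the step.

Still open, from the compounds shown here alone, is how a morpholin-4-yl or a 4-methylpiperazin-1-yl group would fare on this same carbon, with the rest of compound 4 unchanged.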